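A few compounds are considered here, and "the series" means these few. Any claim that something is new, unique, unknown or untested is made for them only; others in the source may bear on it.

In a functional assay on CCRF-CEM cells for antagonist activity at C-X-C chemokine receptor type 4 (Homo sapiens), read by calcium flux, with stated times of 25 min and 90 s (on this read-out higher numbers stand for weaker inhibition and lower numbers for stronger inhibition), compound 1 `CCN1CCN(CCCN(C[C@H]2Cc3ccccc3CN2)[C@H]2CCCc3cccnc32)CC1` gives 33 nM, compound 2 `c1ccc2c(c1)CN[C@@H](CN(CCCCN1CCNCC1)[C@H]1CCCc3cccnc31)C2` gives 66 nM, and compound 3 `c1ccc2c(c1)CN[C@@H](CN(CC[C@@H]1CCCNC1)[C@H]1CCCc3cccnc31)C2` gives 161 nM, the highest of the three numbers, so compound 3 is the weakest inhibitor among them. Compound 4 `NC(=O)N1CCN(CCCN(C[C@H]2Cc3ccccc3CN2)[C@H]2CCCc3cccnc32)CC1` differs from compound 3 in one place: (4-carbamoylpiperazin-1-yl)methyl in place of piperidin-3-yl on a saturated chain carbon, two bonds along the chain from an amine nitrogen. The step that bears most directly on this change is a 4.9-fold higher number from compound 1 to compound 3 (0.69 log units; beyond the scatter), since compound 1 carries (4-ethylpiperazin-1-yl)methyl on the same saturated chain carbon; a 2.4-fold higher number from compound 2 to compound 3 (0.39 log units; beyond the scatter) points the same way. Replacing piperidin-3-yl with a piperazin-1-yl-bearing methyl group is therefore expected to lower the number again, and a 3.2-fold lower number from compound 3 to compound 4 (0.51 log units; beyond the scatter) is anticipated for compound 4. The estimate for compound 4 is 50 nM, with a range from 20 nM to 150 nM.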

Compound 4, half-maximal inhibitory concentration: 959 nM
For compound 4 the middle estimate is 19-fold (1.28 log units) below the measured one; measured number outside the range, above it.
By their numbers in this assay, from the lowest: compounds 1 and 2 (each within the scatter of the next); then compound 3; then compound 4.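

Carbamoyl in place of ethyl on an amine nitrogen in a ring brings a 29-fold higher number from compound 1 to compound 4 (1.46 log units; beyond the scatter) and so, in this set, carrying a piperazine ring does not by itself keep the number low. The group on that ring nitrogen matters as well. The change from the piperazine without carbamoyl gives a 15-fold higher number from compound 2 to compound 4 (1.16 log units; beyond the scatter) and even piperidin-3-yl, the poorest group until now, does better, with a 6.0-fold higher number from compound 3 to compound 4 (0.77 log units; beyond the scatter) as the step to carbamoyl.

No measurement shown explains this loss. On these data alone, whether acetyl or methyl on that same ring nitrogen would raise the number as well remains open.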